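This account rests on a few compounds, and the source may have more. Where it says the series, first, only, none or still open, it means among the compounds named here.

Measured so far in a functional assay (mast cells) for inhibition, with Rattus norvegicus as the target; on this read-out higher numbers stand for an effect only at larger amounts of compound and lower numbers for an effect already at smaller amounts:
- compound 1 `CC1CC/C(=N\Nc2cccc(Br)c2)c2ncc(C(=O)O)c(=O)n21` gives 6700 nM
- compound 2 `C[C@H]1CC/C(=N\Nc2ccc(O)cc2)c2ncc(C(=O)O)c(=O)n21` gives 26200 nM
- compound 3 `CCOc1cccc(N/N=C2\CCC(C)n3c2ncc(C(=O)O)c3=O)c1` gives 4700 nM

Compound 1 holds the second highest of these three numbers, with compound 3 its nearest neighbour and compound 2 furthest off. Compound 4 `Cc1ccc(N/N=C2\CCC(C)n3c2ncc(C(=O)O)c3=O)cc1` has not been measured. It differs from compound 1 by 4-methylphenyl in place of 3-bromophenyl on an amine nitrogen with 4-methylphenyl in place of 3-bromophenyl on an amine nitrogen. Among the measured compounds shown here, the one measured step that replaces the bromo group is a 1.4-fold lower number from compound 1 to compound 3 (0.15 log units; within the scatter) and it stays within the scatter. For the measured compounds named here, compound 2 shows a higher number than compound 1, but no measured step in one place links them. On these data alone, a change beyond the scatter is therefore not expected in this assay and the direction remains open. The estimated move is a 1.2-fold higher number from compound 1 to compound 4 (0.08 log units; within the scatter) and no more. Compound 4 is expected at 8000 nM within an estimated range of 3500 nM to 18000 nM in this read-out.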

Compound 4, half-maximal effective concentration: 280 nM
Estimate against measurement, compound 4: 29-fold (1.46 log units) above, outside the stated range (below it).
By their numbers in this assay, from the lowest: compound 4; then compounds 3 and 1 (each within the scatter of the next); then compound 2.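

In this assay this change reads a 24-fold lower number from compound 1 to compound 4 (1.38 log units; beyond the scatter) and so shows that the aryl group on this amine nitrogen can move the number far, which the earlier step of a 1.4-fold lower number from compound 1 to compound 3 (0.15 log units; within the scatter) did not show. The change swaps both the substituent and its place on the phenyl ring, so this single step cannot separate the two. Nothing available accounts for the size of the step.

On these data alone, it remains open whether the methyl group or its place carries the step. 3-Methylphenyl and 4-bromophenyl would tell these apart, and 4-ethylphenyl would test a longer chain.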